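From a Fluorophenyl to a Phenethyl Group on Sulfur

A few compounds are considered here, and "the series" means these few. Any claim that something is new, unique, unknown or untested is made for them only; others in the source may bear on it.

Measured so far:
compound 1 `Nc1ccccc1NC(=O)/C=C/c1ccc(CSc2cccc(F)c2)cc1`: 9.08%
compound 2 `Nc1ccccc1NC(=O)/C=C/c1ccc(CSc2ccc(F)cc2)cc1`: 24.6%

In a functional assay on A-375 cells (Homo sapiens) for inhibition, read by CCK-8 assay, with a stated time of 72 h, tested at 8 uM (a lower number here means less inhibition of growth, a higher number more inhibition of growth at the concentration tested), compound 2 gives 24.6%, the higher of the two numbers available. The next molecule, compound 3 `Nc1ccccc1NC(=O)/C=C/c1ccc(CSCCc2ccccc2)cc1`, keeps the shared core and changes only the group on the sulfur, with phenethyl in place of 4-fluorophenyl on a sulfur.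

Within the data shown here, only one measured step bears on this change: a number 15.5 percentage points higher from compound 1 to compound 2 (beyond the scatter). This modest step came from 4-fluorophenyl replacing 3-fluorophenyl, and it shows that a small edit at this place can move the number beyond the scatter. It gives no direction for the new group, since neither measured compound carries phenethyl. With just two data points, a modest step is the reasonable expectation, leaning slightly downward, as compound 2 is the higher of the pair at 24.6%. The expected change is a number 6.6 percentage points lower from compound 2 to compound 3 (within the scatter), though a step in the other direction would not be surprising. For compound 3 the estimated value is 18%, with an expected range from 5% to 40%.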

Compound 3, percent growth inhibition at one concentration: 37.4%
The estimate for compound 3 lay 19.4 percentage points below the measured number; low and high end bracket the measured number.
By their numbers in this assay, from the lowest: compound 1; then compound 2; then compound 3.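

Compound 1 and compound 2 differ only in where the fluorine sits on a fluorophenyl group, whereas this change replaces the whole group on the sulfur. In this assay, that larger change gives a number 12.8 percentage points higher from compound 2 to compound 3 (beyond the scatter), so a fluorophenyl group is not needed for the highest number in this small set, and phenethyl, which carries no fluorine, takes that place. The gap across the set, a number 28.3 percentage points higher from compound 1 to compound 3 (beyond the scatter), shows that among these three compounds, which share the same core, the group on the sulfur can shift growth inhibition well beyond the usual scatter. No supporting measurement is available to explain why phenethyl gives the higher number.

Phenethyl differs from 4-fluorophenyl in two ways at once, having a saturated chain and having no fluorine, so these compounds cannot show which difference matters. A fluorinated phenethyl, an unsubstituted phenyl, a benzyl or a longer chain ending in an amine would each help separate those effects, and all of these readings remain single-concentration percentages rather than full measures of potency.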